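A few compounds are considered here, and "the series" means these few. Any claim that something is new, unique, unknown or untested is made for them only; others in the source may bear on it.

Of the compounds shown here, three of a shared core have been measured in a functional assay on A549 cells (Homo sapiens) for antiproliferative activity, read by MTT assay, with a stated time of 48 h; on this read-out higher numbers stand for weaker inhibition and lower numbers for stronger inhibition. Compound 1 `N#CC1=C(N)Oc2c(c3nc4ccccc4nc3c3ccccc23)C12C(=O)N(Cc1cnnn1-c1cccc(Br)c1)c1ccccc12` reaches only a limit of this assay, > 50000 nM. Compound 2 `N#CC1=C(N)Oc2c(c3nc4ccccc4nc3c3ccccc23)C12C(=O)N(Cc1cnnn1-c1ccc(N)cc1)c1ccccc12` likewise gives only a limit, > 50000 nM. The step from compound 1 to compound 2 is a step that the two limits leave unreadable from compound 1 to compound 2: a 4-aminophenyl in place of a 3-bromophenyl on an aromatic nitrogen. For the measured compounds named here, compound 3 `Cc1cccc(-n2nncc2CN2C(=O)C3(C(C#N)=C(N)Oc4c(N)cc5nc6ccccc6nc5c43)c3ccccc32)c1` is the one compound with a number: in this assay compound 3 gives 12300 nM. The other two values sit at the limit of > 50000 nM in this assay, at which 2 of the 3 values shown sit.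

Compound 4 `N#CC1=C(N)Oc2c(N)cc3nc4ccccc4nc3c2C12C(=O)N(Cc1cnnn1-c1cccc(Br)c1)c1ccccc12` differs from compound 3 by bromo in place of methyl on an aromatic carbon. Going by the values given here, no measured step bears on this exchange; the only measured step runs between two limits and says nothing about bromo against methyl. Compound 1 carries the same 3-bromophenyl as compound 4 but lacks the amino group on the core that compound 3 and compound 4 share, so its limit cannot be read across. With nothing pointing one way or the other, compound 4 is expected to stand near compound 3, with a step of a 1.2-fold higher number from compound 3 to compound 4 (0.09 log units; within the scatter) that lies within the scatter. Compound 4 is therefore estimated at 15000 nM, within a range from 4000 nM to 50000 nM, with a real chance that this assay reports only a limit.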

Compound 4, half-maximal inhibitory concentration: 18900 nM
The estimate for compound 4 lay 1.3-fold (0.10 log units) below the measured number, and the stated range covers the measured number.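

In this assay, bromo in place of methyl on this six-membered aromatic ring gives a 1.5-fold higher number from compound 3 to compound 4 (0.19 log units; within the scatter), so compound 3 and compound 4 cannot be told apart at this position, meta to a large group. For the compounds shown here, this is the first step in the set with a readable size, since the step between compound 1 and compound 2 runs between two limits and cannot be read. Nothing measured here offers a cause for how closely the two values lie.

As far as these compounds go, whether this position tolerates other groups equally remains open, for example a methoxy group, an amine or a carboxylic acid, all of which differ from methyl and bromo in their atoms. The core of compound 1 has no 3-methylphenyl partner among the compounds shown, so it remains unknown whether the same pair would read alike there.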